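The source may hold more compounds than are shown below. What is called first, only, known or untested is meant among the compounds shown, and "the series" means these compounds.

Compound 1 `CC(C)Nc1nc(/C=C/c2ccccc2)nc2ccsc12` gives > 1000000 nM (a limit)
Compound 2 `Brc1ccc(Nc2nc(/C=C/c3ccccc3)nc3ccsc23)cc1` gives > 1000000 nM (a limit)

Both results come from a functional assay on L02 cells (Homo sapiens) for inhibition, read by Griess assay, with stated times of 1 h and 24 h; a lower number here means a stronger inhibitor, a higher number a weaker inhibitor. In this assay compound 2 stands at > 1000000 nM, which is a limit and not a number. Going by the values given here, the same picture holds across the series so far: the limit of > 1000000 nM in this assay, at which 2 of the 2 values shown sit. Compound 3 `Brc1ccc(CNc2nc(/C=C/c3ccccc3)nc3ccsc23)cc1` has 4-bromobenzyl in place of 4-bromophenyl on a nitrogen on an aromatic ring. Among the compounds with values here, the only measured step, a step that the two limits leave unreadable from compound 1 to compound 2, has no readable size, so it points in no direction, and no step beyond the scatter is expected. The expected step is a number no higher from compound 2 to compound 3 (the limit leaves the size open). For compound 3 the estimate is 1000000 nM, with an expected range of 200000 nM to 2000000 nM, and another limit is quite likely.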

Compound 3, half-maximal inhibitory concentration: > 1000000 nM
Compound 3 was reported as a limit; the forecaster's own chance of this, stated with the estimate: 65%; the middle value lies on the limit itself.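

Compound 3 gives only a limit, as do compound 1 and compound 2, so no step among these compounds can be read: the limit of > 1000000 nM in this assay, at which 3 of the 3 values shown sit. The compounds shown leave open whether any group on that nitrogen gives a measurable value in this assay.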